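Oxan-4-yl in place of cyclopentyl on compound 2

The source may hold more compounds than are shown below. What is called first, only, known or untested is meant among the compounds shown, and "the series" means these compounds.

Compound 1 `CN1CCN(c2ccc(Nc3ncc4nc([S+]([O-])Cc5cccnc5)n(C5CCOCC5)c4n3)cc2)CC1`: > 10000 nM (a limit)
Compound 2 `CN1CCN(c2ccc(Nc3ncc4nc([S+]([O-])c5ccccc5)n(C5CCCC5)c4n3)cc2)CC1`: 64.7 nM

Both entries come from a functional assay on HCC827 cells (Homo sapiens) for antiproliferative activity, read by MTT assay, with a stated time of 72 h; a lower number here means a stronger inhibitor, a higher number a weaker inhibitor. For the measured compounds named here, compound 2, at 64.7 nM, holds the only actual number. Compound 3 `CN1CCN(c2ccc(Nc3ncc4nc([S+]([O-])c5ccccc5)n(C5CCOCC5)c4n3)cc2)CC1` carries oxan-4-yl in place of cyclopentyl on an aromatic nitrogen. Going by the values given here, no measured step isolates this change. Compound 1, which also carries oxan-4-yl, stands at the limit > 10000 nM, but it differs from compound 3 in its sulfoxide substituent as well, so it gives only a weak hint. A moderate weakening in this assay is expected, and the estimated change is a 2.3-fold higher number from compound 2 to compound 3 (0.37 log units; beyond the scatter). Compound 3 is estimated at 150 nM, with an expected range of 30 nM to 1000 nM.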

Compound 3, half-maximal inhibitory concentration: 411 nM
Compound 3: middle estimate off by 2.7-fold (0.44 log units), on the low side, within the range that was stated.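

In this assay the step from cyclopentyl to oxan-4-yl on the aromatic nitrogen is a 6.4-fold higher number from compound 2 to compound 3 (0.80 log units; beyond the scatter) with phenyl held on the sulfur. With oxan-4-yl held, phenyl in place of (pyridin-3-yl)methyl on the sulfur gives an at least 24-fold lower number from compound 1 to compound 3 (1.38 log units; beyond the scatter) and shows that oxan-4-yl still allows activity in compound 3. Compound 1 stands at a limit and not at a number, so this second step is only a bound: the limit of > 10000 nM in this assay, at which 1 of the 3 values shown sits.

On these data alone, whether the ring oxygen or the ring size drives the first step stays open, and cyclohexyl or piperidin-4-yl on that nitrogen would separate the two. Also open, as far as these compounds go, is how (pyridin-3-yl)methyl on the sulfur behaves with cyclopentyl on the nitrogen.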